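Swapping the pyridine of compound 1 for an oxazole

The source may report more compounds than this note shows. Statements on the series, on what has been measured and on what is new or still open speak of the compounds shown alone.

Compound 1, with the structure `CC1(C)OC[C@@H](C/C=C\CCC(=O)O)[C@@H](c2cccnc2)O1`, is one of three close relatives tested in an assay on isolated protein for inhibition of Thromboxane-A synthase (Homo sapiens); a higher number here means a weaker inhibitor, a lower number a stronger inhibitor. In this assay compound 1 gives 120 nM, which is the second highest of the three numbers. Its nearest neighbour is compound 3, `CC1(C)OC[C@@H](C/C=C\CCC(=O)O)[C@@H](c2cncs2)O1`, which gives 80 nM; the step of a 1.5-fold lower number from compound 1 to compound 3 (0.18 log units; within the scatter) lies within the scatter. Its furthest neighbour is compound 2, `CC1(C)OC[C@@H](C/C=C\CCC(=O)O)[C@@H](c2ccnnc2)O1`, which gives 7400 nM; the step of a 62-fold higher number from compound 1 to compound 2 (1.79 log units; beyond the scatter) is large and well beyond the scatter.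

Compound 4, `CC1(C)OC[C@@H](C/C=C\CCC(=O)O)[C@@H](c2cnco2)O1`, differs from compound 1 in one place: 1,3-oxazol-5-yl in place of pyridin-3-yl on a saturated ring carbon. Going by the values given here, two measured steps bear on this change. Both replace the pyridin-3-yl of compound 1 with another aromatic ring at the same position, and the outcomes are opposite in size: the five-membered 1,3-thiazol-5-yl of compound 3 leaves the number essentially unchanged, while the six-membered pyridazin-4-yl of compound 2 raises it greatly. The new ring of compound 4 is five-membered, like that of compound 3, but carries an oxygen rather than a sulfur. The expectation is therefore an uncertain step upward in this assay, smaller than the step to compound 2 but likely beyond the scatter, as a 6.7-fold higher number from compound 1 to compound 4 (0.82 log units; beyond the scatter). For compound 4 the estimated value is 800 nM, with a range from 150 nM to 4000 nM.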

Compound 4, half-maximal inhibitory concentration: > 10000 nM
Compound 4 ended at the assay's limit (the forecaster's own chance of this, stated with the estimate: 5%); at least 12-fold (1.09 log units) between middle value and limit.
By their numbers in this assay, from the lowest: compounds 3 and 1 (each within the scatter of the next); then compound 2. At a limit, above all of these: compound 4.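

In this assay compound 4 ends at a limit of the assay, > 10000 nM, and not at a number: the limit of > 10000 nM in this assay, at which 1 of the 4 values shown sits. Exchanging the 1,3-thiazol-5-yl for the 1,3-oxazol-5-yl, both five-membered aromatic rings, gives an at least 120-fold higher number from compound 3 to compound 4 (2.09 log units; beyond the scatter), and the exchange of pyridin-3-yl gives an at least 83-fold higher number from compound 1 to compound 4 (1.92 log units; beyond the scatter), so a five-membered ring on this saturated ring carbon does not by itself keep the number low, and the identity of the ring's hetero atoms counts heavily here. The comparison with the pyridazin-4-yl ring gives an at least 1.3-fold higher number from compound 2 to compound 4 (0.13 log units; that floor lies within the scatter), a floor that does not separate compound 4 from compound 2, so two of the four rings tried sit far from compounds 1 and 3 on the weak side.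

On these data alone, how far beyond its limit compound 4 lies stays unknown, and so does its true distance from compound 2. As far as these compounds go, whether a plain phenyl ring or a 1,3-thiazol-4-yl ring on this carbon would stay with compounds 1 and 3 or fall with compounds 2 and 4 also remains open.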